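This account rests on a few compounds, and the source may have more. Where it says the series, first, only, none or still open, it means among the compounds named here.

Measured compounds:
Compound 1, `[N-]=[N+]=N[C@@H]1C(n2ccc(=O)[nH]c2=O)[Se][C@H](CO)[C@H]1O`: in a functional assay on A549 cells (Homo sapiens) for cytotoxicity, read by sulforhodamine B assay (a lower number here means a stronger inhibitor, a higher number a weaker inhibitor), compound 1 gives > 100000 nM, which is a limit of the assay rather than a number.
Compound 2, `Cc1cn(C2[Se][C@H](CO)[C@@H](O)[C@@H]2N=[N+]=[N-])c(=O)[nH]c1=O`: in this assay compound 2 gives > 100000 nM, again only a limit.
Compound 3, `O=c1ccn(C2[Se][C@H](CO)[C@@H](O)[C@@H]2O)c(=O)[nH]1`: in this assay compound 3 gives > 100000 nM, again only a limit.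

Compound 3 therefore stands at a limit, and so do the other two values shown, all of them at the limit of > 100000 nM in this assay, at which 3 of the 3 values shown sit. Compound 4, `Cc1cn(C2[Se][C@H](CO)[C@@H](O)[C@@H]2O)c(=O)[nH]c1=O`, is reached from compound 3 by one change: methyl in place of hydrogen on an aromatic carbon. The same change has already been made once, from compound 1 to compound 2, where the step came out as a step that the two limits leave unreadable from compound 1 to compound 2. The other measured step, a step that the two limits leave unreadable from compound 1 to compound 3, is unreadable for the same reason. Among the measured compounds shown here, no measured step gives a size in either direction, and nothing in these values points to compound 4 leaving the limit. The estimated step of a number no higher from compound 3 to compound 4 (the limit leaves the size open) is expected to be nothing beyond the scatter. Compound 4 is therefore expected to give about 100000 nM in this assay, in a range from 30000 nM to 300000 nM, most likely reported again as a limit.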

Compound 4, half-maximal inhibitory concentration: > 100000 nM
Compound 4 was reported as a limit (the forecaster's own chance of this, stated with the estimate: 90%); the middle value sits exactly at the limit.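

In this assay compound 4 gives > 100000 nM, again a limit, so neither its step from compound 3 nor its step from compound 2 can be read: the limit of > 100000 nM in this assay, at which 4 of the 4 values shown sit.

The compounds shown leave open whether, in this assay, methyl in place of hydrogen or hydroxy in place of azido has any effect, and of what size.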